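The source may report more compounds than this note shows. Statements on the series, on what has been measured and on what is new or still open speak of the compounds shown alone.

Measured so far in a functional assay on MCF7 cells (Homo sapiens) for antiproliferative activity, read by MTT assay, with a stated time of 72 h; a higher number here means a weaker inhibitor, a lower number a stronger inhibitor:
- compound 1 `CC(C)(C)c1cn(C[C@H](O)[C@H]2OC(=O)C(OCc3ccccc3)=C2OCc2ccccc2)nn1`: 730 nM
- compound 2 `CC(C)(C)OC(=O)N1CCN(C(=S)SCc2cn(C[C@H](O)[C@H]3OC(=O)C(OCc4ccccc4)=C3OCc3ccccc3)nn2)CC1`: a limit of this assay only, > 100000 nM
- compound 3 `O=C1O/C(=C\Cn2cc(-c3cc(C(F)(F)F)cc(C(F)(F)F)c3)nn2)C(OCc2ccccc2)=C1OCc1ccccc1`: a limit of this assay only, > 100000 nM

Going by the values given here, compound 1 is the only member of the set with a number in this assay; the other two values are limits, and both sit at the limit of > 100000 nM in this assay, at which 2 of the 3 values shown sit. Among the compounds with values here, no pair of measured compounds differs in a single place, so no measured step is available to calibrate the change under consideration.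

Compound 4 `O=C1O[C@H]([C@@H](O)Cn2ccnn2)C(OCc2ccccc2)=C1OCc1ccccc1` is not yet measured. Relative to compound 1 it carries hydrogen in place of tert-butyl on an aromatic carbon on the shared core. Nothing in the measured data gives the size of such a change, so the expectation rests on the general observation that a small substituent is taken away while the rest of compound 1 is kept. Compound 1 stands as the reference point.

Compound 4 is expected to be somewhat weaker than compound 1, a step of a 4.1-fold higher number from compound 1 to compound 4 (0.61 log units; beyond the scatter) that would be beyond the usual scatter but not large. Compound 4 is estimated at 3000 nM, with a range from 700 nM to 30000 nM.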

Compound 4, half-maximal inhibitory concentration: > 100000 nM
Compound 4 ended at the assay's limit (the forecaster's own chance of this, stated with the estimate: 25%); middle value at least 33-fold (1.52 log units) from the limit.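

In this assay, the carbon of the five-membered aromatic ring that bears tert-butyl in compound 1 now has a measured step: hydrogen in place of tert-butyl gives an at least 130-fold higher number from compound 1 to compound 4 (2.13 log units; beyond the scatter). Going by these compounds alone, only this group changes and the rest of compound 1 is kept, so the measurable activity of compound 1 is tied to a group at this carbon, a link that the earlier compounds could not show because none of them formed a single-place pair. The step ends on a limit of the assay for compound 4 rather than a number, so its full size stays unfixed: the limit of > 100000 nM in this assay, at which 3 of the 4 values shown sit.

From the compounds shown here alone, whether methyl, isopropyl or cyclohexyl at this carbon would give a number in this assay remains open. Within the data shown here, with tert-butyl as the only group here that gives a number, no trend at this position can be read.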